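Methyl for hydrogen on a phenolic oxygen of a nitro-benzimidazole

A few compounds are considered here, and "the series" means these few. Any claim that something is new, unique, unknown or untested is made for them only; others in the source may bear on it.

Two compounds have been measured so far:
compound 1, `COc1ccc(-c2nc3cc([N+](=O)[O-])ccc3[nH]2)c(OC)c1OC`, gives 58.9% in a functional assay on aorta (Rattus norvegicus, strain Wistar) for inhibition, with a stated time of 60 min; on this read-out higher numbers stand for larger maximal responses and lower numbers for smaller maximal responses
compound 2, `COc1cc(-c2nc3cc([N+](=O)[O-])ccc3[nH]2)ccc1O`, gives 55.2% in this assay

Compound 1 and compound 2 share a core and differ only in the substituents on the pendant aromatic ring. In this assay compound 2 gives 55.2%, and the nearest number, that of compound 1, sits within the scatter of it, so the two compounds cannot be told apart on the numbers shown. Going by the values given here, no step between measured compounds is available here.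

Compound 3, `COc1ccc(-c2nc3cc([N+](=O)[O-])ccc3[nH]2)cc1OC`, has not yet been measured. Its difference from compound 2 is methyl in place of hydrogen on an oxygen on an aromatic ring. Since compound 1 and compound 2, which carry different oxygen substituents on that ring, are not separated beyond the scatter, no step beyond the scatter is expected in this assay from this change either. The step from compound 2 to compound 3 is estimated at a number 1.8 percentage points higher from compound 2 to compound 3 (within the scatter). Compound 3 is therefore expected to give about 57%, with a range from 45% to 70%.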

Compound 3, largest response reached (Emax), in percent of the reference or control that the assay uses: 36.3%
Compound 3: middle estimate off by 20.7 percentage points, on the high side, and the stated range ends above it.
By their numbers in this assay, from the lowest: compound 3; then compounds 2 and 1 (each within the scatter of the next).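

In this assay, the swap of hydroxy to methoxy on this ring is not a silent change: methyl in place of hydrogen on an oxygen on an aromatic ring gives a number 18.9 percentage points lower from compound 2 to compound 3 (beyond the scatter), a step beyond the scatter. The neighbour on the other side reads the same way, since hydrogen in place of methoxy on an aromatic carbon gives a number 22.6 percentage points lower from compound 1 to compound 3 (beyond the scatter), so compound 3 stands lowest of the three and apart from both compounds that differ from it in one place. Compound 1 and compound 2 could not be told apart, and that closeness gave no sign that the maximal response in this assay responds to either single change on the pendant ring.

Going by these compounds, whether the lower response belongs to the methoxy group at this oxygen alone or to the whole set of ring substituents stays open, as does what an ethoxy group on that oxygen, or an amine in place of the hydroxy group, would give. Nothing at hand explains why these two single changes shift the maximal response.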